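The source may report more compounds than this note shows. Statements on the series, on what has been measured and on what is new or still open speak of the compounds shown alone.

Notes on the series. Among the measured compounds shown here, compound 1 `O=C(Nc1ccc(Sc2nc3ccccc3s2)cc1)c1cc(Br)cc(Br)c1O` is the only compound with a number in an ADME assay on HEK293 cells (Homo sapiens) for cytotoxicity, read by reporter gene assay and resazurin assay, with a stated time of 48 h; a higher number here means that more compound is tolerated, a lower number that less compound is tolerated: compound 1 gives 66000 nM. Compound 2 `COc1c(Br)cc(Br)cc1C(=O)Nc1cccc(Cl)c1` reaches only a limit of the assay in this assay, where compound 2 gives > 100000 nM; this is the limit of > 100000 nM in this assay, at which 1 of the 2 values shown sits. Compound 3 `COc1c(Br)cccc1C(=O)Nc1ccc(Sc2nc3ccccc3s2)cc1` has not yet been run in this assay. Compound 3 differs from compound 1 by a group of 9 heavy atoms (7 carbon, 1 oxygen, 1 bromine; one six-membered aromatic ring of carbon only) in place of a group of 9 heavy atoms (6 carbon, 1 oxygen, 2 bromine; one six-membered aromatic ring of carbon only), on a carbonyl carbon. For the measured compounds named here, no measured step of this kind exists. The step of a 1.5-fold higher number from compound 1 to compound 3 (0.18 log units; within the scatter) is expected to stay within the scatter, if anything toward more tolerated. Compound 3 is estimated at 100000 nM in this assay, expected between 45000 nM and 220000 nM.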

Compound 3, half-maximal cytotoxic concentration: > 100000 nM
Compound 3: a limit, no number; the forecaster's own chance of this, stated with the estimate: 45%; the middle value sits exactly at the limit.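

Exchanging the 3,5-dibromo-2-hydroxyphenyl group on the carbonyl carbon for a group with one bromine and no hydrogen-bond donor gives an at least 1.5-fold higher number from compound 1 to compound 3 (0.18 log units; that floor lies within the scatter) in this assay. Compound 3 gives > 100000 nM, which is a limit of the assay and not a number. The step is therefore a floor and not a measured size, because the top of the assay range is reached: the limit of > 100000 nM in this assay, at which 2 of the 3 values shown sit.

The exchange alters the bromine and hydrogen-bond donor counts together, and the compounds shown do not separate the two. As far as these compounds go, how a carboxylic acid or an amine on this aromatic ring would read remains open.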